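The source may report more compounds than this note shows. Statements on the series, on what has been measured and on what is new or still open speak of the compounds shown alone.

Of the compounds shown here, two sharing one core have been measured so far in a functional assay on MCF7 cells (Homo sapiens) for antiproliferative activity, read by MTT assay, with a stated time of 24 h; a lower number here means a stronger inhibitor, a higher number a weaker inhibitor. Compound 1 `Cc1ccc(C)c(S(=O)(=O)n2c(-c3cn(-c4ccccc4)nc3-c3ccc(F)cc3)nc3ccccc32)c1` gives 430 nM, the lower of the two numbers, while compound 2 `O=S(=O)(c1ccc(Br)cc1)n1c(-c2cn(-c3ccccc3)nc2-c2ccc(F)cc2)nc2ccccc21` gives 2630 nM. The next compound, compound 3 `Cc1ccc(C)c(S(=O)(=O)n2c(-c3cn(-c4ccccc4)nc3-c3ccc(C(F)(F)F)cc3)nc3ccccc32)c1`, keeps the 2,5-dimethylphenyl on the sulfonyl sulfur of compound 1 and carries its change elsewhere: trifluoromethyl in place of fluoro on an aromatic carbon. Trifluoromethyl stands in place of fluoro on an aromatic carbon, so 4-fluorophenyl becomes 4-(trifluoromethyl)phenyl. Within the data shown here, only one measured step bears on this, and only indirectly: a 6.1-fold higher number from compound 1 to compound 2 (0.79 log units; beyond the scatter). Among the measured compounds shown here, that modest step, beyond the scatter, was made on the sulfonyl sulfur, and no measured compound varies the fluoro, so the direction at this new place is not established by the data. A step no larger than that one is therefore expected in this assay, leaning slightly towards a higher number, with no change beyond the scatter remaining quite possible. The expected change is a 1.5-fold higher number from compound 1 to compound 3 (0.18 log units; within the scatter). For compound 3 the estimated value is 650 nM, with an expected range of 200 nM to 2200 nM.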

Compound 3, half-maximal inhibitory concentration: 170 nM
For compound 3 the middle estimate is 3.8-fold (0.58 log units) above the measured one; the whole stated range lies above it.
By their numbers in this assay, from the lowest: compound 3; then compound 1; then compound 2.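

Among these compounds, the change from fluoro to trifluoromethyl, on an aromatic carbon para to a large group, is the first measured change at this place, and in this assay it gives a 2.5-fold lower number from compound 1 to compound 3 (0.40 log units; beyond the scatter) while the 2,5-dimethylphenyl on the sulfonyl sulfur stays as it was. Among the compounds shown here, this place therefore responds to substitution, and a group of more heavy atoms than fluoro is accepted here without any rise in the number, whereas the only earlier step, made on the sulfonyl sulfur, was a 6.1-fold higher number from compound 1 to compound 2 (0.79 log units; beyond the scatter) and ran the other way. Nothing among the data shown accounts for why the number falls with this exchange.

With only fluoro and trifluoromethyl at this place, the compounds shown leave open whether the trend would continue with other groups, such as a chlorine atom, a methyl, a methoxy, an amine or a carboxylic acid, or with a plain hydrogen as the reference point. They also leave open whether the same exchange would lower the number when 4-bromophenyl, as in compound 2, sits on the sulfonyl sulfur, since this one pair rests on the 2,5-dimethylphenyl alone.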